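A few compounds are considered here, and "the series" means these few. Any claim that something is new, unique, unknown or untested is made for them only; others in the source may bear on it.

Of the compounds shown here, three have so far been measured in a functional assay on Hs-578T cells (Homo sapiens) for cytotoxicity, read by sulforhodamine B assay, with a stated time of 48 h; a lower number here means a stronger inhibitor of growth, a higher number a weaker inhibitor of growth. Compound 1 `ClCc1ccc(Cn2cnc3c(Cl)ncnc32)cc1` gives 10200 nM in this assay. Compound 2 `Nc1nc(Cl)c2ncn(Cc3ccc(CCl)cc3)c2n1` carries one change relative to compound 1, namely (amino in place of hydrogen on an aromatic carbon); in this assay compound 2 gives 29500 nM, so that a 2.9-fold higher number from compound 1 to compound 2 (0.46 log units; beyond the scatter). Compound 3 `ClCc1ccccc1Cn1cnc2c(Cl)ncnc21` is built from the same atoms as compound 1, joined differently; how the two cores differ is not broken down here. In this assay compound 3 gives 2290 nM, the lowest of the three numbers, and its gap to compound 1 as well as to compound 2 lies beyond the scatter of repeated measurements.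

Compound 4 `Nc1nc(Cl)c2ncn(Cc3ccccc3CCl)c2n1` has not yet been measured. It differs from compound 3 by amino in place of hydrogen on an aromatic carbon, and the surroundings of the place are described in the same words as for the change from compound 1 to compound 2, so this is the same change seen a second time. For the measured compounds named here, the only measured instance of it is the step from compound 1 to compound 2, which weakened growth inhibition by a modest amount that was nonetheless beyond the scatter. Resting on that single earlier instance, the expected step is a 2.7-fold higher number from compound 3 to compound 4 (0.43 log units; beyond the scatter). For compound 4 the expected value in this assay is therefore 6200 nM. The expected range for compound 4 runs from 2500 nM to 15000 nM.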

Compound 4, concentration for 50% growth inhibition: 7760 nM
Compound 4: the middle estimate sits 1.3-fold (0.10 log units) below what was measured, within the range that was stated.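

Putting amino in place of hydrogen on an aromatic carbon of the core of compound 3 gives, in this assay, a 3.4-fold higher number from compound 3 to compound 4 (0.53 log units; beyond the scatter), so growth inhibition weakens here just as it did on the core of compound 1. The two instances of the change point the same way and do not differ in size beyond what repeated measurements would scatter by: the same change on two cores in this assay, a 2.9-fold higher number (0.46 log units; beyond the scatter) from compound 1 to compound 2 and a 3.4-fold higher number (0.53 log units; beyond the scatter) from compound 3 to compound 4, 1.2-fold (0.07 log units) apart, within the scatter of two such steps This shows that, within these two pairs, the step carries over from one core to the other with its direction and size kept, but two pairs on closely related cores, read in a single assay on one cell line, do not show that it would hold on a core of another kind, and they say nothing about why the number rises.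

The compounds shown carry only hydrogen or amino at this place on the ring, so they leave open what a methyl group, a methoxy group or a longer alkylamine would do there. Going by these compounds, it also stays open whether the step would keep its size if the chloromethyl group were replaced by a hydroxymethyl group or a plain methyl group.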